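A Methyl Added to a Phenyl Ring: Expected Binding

This account rests on a few compounds, and the source may have more. Where it says the series, first, only, none or still open, it means among the compounds named here.

This account follows two measured compounds and one that awaits measurement, all sharing the same core. In an assay on CHO cells for displacement of a labelled ligand from adenosine receptor A1 (Homo sapiens), read by scintillation counting, with a stated time of 90 min, in the presence of a further agent that is not named here (on this read-out lower numbers stand for stronger inhibition and higher numbers for weaker inhibition), compound 2, with structure `CCCn1c(=O)[nH]c2nc(-c3ccc(S(=O)(=O)N4CCN(c5ccccc5)CC4)cc3)[nH]c2c1=O`, gives 364 nM. Compound 1, with structure `CCCn1c(=O)c2[nH]c(-c3ccc(S(=O)(=O)N4CCN(c5ccc(Cl)cc5)CC4)cc3)nc2n(C)c1=O`, is a related compound in which the core differs and the pendant aromatic ring carries a different substituent. In this assay compound 1 reaches only > 1000 nM, which is a limit of the assay and not a number. Within the data shown here, compound 2 therefore stands as the only real number in this assay, while the remaining value is a limit, as noted in the limit of > 1000 nM in this assay, at which 1 of the 2 values shown sits. Among the measured compounds shown here, no pair of measured compounds differs in a single place, so no measured step is available to guide the next change.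

Compound 3, with structure `CCCn1c(=O)[nH]c2nc(-c3ccc(S(=O)(=O)N4CCN(c5ccc(C)cc5)CC4)cc3)[nH]c2c1=O`, differs from compound 2 by methyl in place of hydrogen on an aromatic carbon. For the measured compounds named here, with no measured step of this kind to lean on, the change is expected to fall within the scatter of repeated measurements, neither clearly stronger nor weaker, and compound 3 is expected to show a step of a 1.1-fold lower number from compound 2 to compound 3 (0.06 log units; within the scatter) in this assay. Compound 3 is accordingly estimated at 320 nM, within a range from 110 nM to 950 nM.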

Compound 3, inhibition constant: > 1000 nM
Compound 3: a limit, no number (the forecaster's own chance of this, stated with the estimate: 15%); middle value at least 3.1-fold (0.49 log units) from the limit.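

Among these compounds, this is the first step in this assay that changes a single place, and it shows that this position does not tolerate every change equally: going from phenyl to 4-methylphenyl, with one carbon added on an aromatic carbon para to a large group, gives an at least 2.7-fold higher number from compound 2 to compound 3 (0.43 log units; beyond the scatter). Compound 3 gives > 1000 nM, which is a limit of the assay and not a number, so the step is known from one side only and its full size stays undefined. Compound 2 thus remains the only compound in the series with a real number, and the other values give no scale on which to place the loss: the limit of > 1000 nM in this assay, at which 2 of the 3 values shown sit.

On these data alone, it remains open how far compound 3 lies past its limit, and whether a different group at the same place, such as fluorine, methoxy or an amine, would be met in the same way as methyl. Also open, as far as these compounds go, is whether methyl in place of hydrogen would give a similar step on the core of compound 1, or at another place on the same phenyl ring.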